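Hydrazone aryl variation: hydroxyphenyl replacement in compound 3

The source may hold more compounds than are shown below. What is called first, only, known or untested is meant among the compounds shown, and "the series" means these compounds.

Within the data shown here, compound 2 `CN(C)CCn1cnnc1-c1cc(Oc2ccc(NC(=O)N/N=C/c3ccc(O)c(F)c3)cc2F)ccn1` gives 3310 nM in a functional assay on HT-29 cells (Homo sapiens) for cytotoxicity, read by MTT assay, with a stated time of 72 h (a lower number here means a stronger inhibitor, a higher number a weaker inhibitor), the highest of the two numbers so far; the nearest is compound 1 `CN(C)CCn1cnnc1-c1cc(Oc2ccc(NC(=O)N/N=C/c3ccc(Cl)cc3)cc2F)ccn1` with 530 nM. Among the measured compounds shown here, the one measured step, a 6.2-fold higher number from compound 1 to compound 2 (0.80 log units; beyond the scatter), changes the same aryl group. Compound 3 `CN(C)CCn1cnnc1-c1cc(Oc2ccc(NC(=O)N/N=C/c3cccc(O)c3)cc2F)ccn1` differs from compound 2 by 3-hydroxyphenyl in place of 3-fluoro-4-hydroxyphenyl on a carbon with a double bond to nitrogen. For the measured compounds named here, no measured step covers this exact change, so it is judged only loosely from the step to compound 2, and the expected step of a 1.3-fold lower number from compound 2 to compound 3 (0.12 log units; within the scatter) is small. Compound 3 is estimated at 2500 nM, expected range 800 nM to 8000 nM.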

Compound 3, half-maximal inhibitory concentration: 330 nM
For compound 3 the middle estimate is 7.6-fold (0.88 log units) above the measured one; measured number outside the range, below it.
By their numbers in this assay, from the lowest: compounds 3 and 1 (each within the scatter of the next); then compound 2.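

In this assay, on a carbon with a double bond to nitrogen, a hydroxyl on the aryl ring does not by itself bring a high number: 3-hydroxyphenyl in place of 3-fluoro-4-hydroxyphenyl gives a 10-fold lower number from compound 2 to compound 3 (1.00 log units; beyond the scatter), and that step moves the hydroxyl and removes the fluorine together. 3-Hydroxyphenyl in place of 4-chlorophenyl gives a 1.6-fold lower number from compound 1 to compound 3 (0.21 log units; within the scatter), so the two groups cannot be told apart here. No supporting data explain these differences.

The effects of fluorine and hydroxyl position remain unseparated, since 4-hydroxyphenyl and 3-fluorophenyl are absent from the compounds shown. On these data alone, how an amine or a carboxylic acid on this ring would read is also open.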